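Chloro for bromo on the aryl ketone of compound 3

The compounds below may be only part of what the source reports. "The series", "measured", "known", "first", "only" and "open" are said of these compounds alone.

The compounds measured so far:
compound 1, `COc1ccccc1/C=C(/SCc1ccc(Cl)c(Cl)c1)C(=O)c1ccc(Cl)cc1`, 10000 nM
compound 2, `O=C(/C(=C\c1ccc[nH]1)SCc1ccc(Cl)cc1)c1ccc(Cl)cc1`, 10000 nM
compound 3, `COc1ccccc1/C=C(/SCc1ccc(Cl)cc1)C(=O)c1ccc(Br)cc1`, 1000 nM

All three were tested in a functional assay on DU-145 cells (Homo sapiens) for inhibition, read by trypan blue exclusion, with a stated time of 96 h; on this read-out higher numbers stand for weaker inhibition of growth and lower numbers for stronger inhibition of growth. Compound 3 stands lowest of the three values: compound 1 gives a value 10000 nM that lies beyond the scatter above it, and compound 2 gives 10000 nM, equally far above. Nothing in these three pairs is a single-point change, so none of them tells directly how one group swap shifts the read-out.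

Compound 4, `COc1ccccc1/C=C(/SCc1ccc(Cl)cc1)C(=O)c1ccc(Cl)cc1`, has not yet been measured. It differs from compound 3 in one place: chloro in place of bromo on an aromatic carbon. Within the data shown here, this is a halogen exchange on the aryl ketone, and among the measured compounds there is no pair that isolates it; compound 1 and compound 2 carry chloro at that position but differ from compound 3 elsewhere as well.

For that reason compound 4 is expected to behave much like compound 3, with a step of a 1.8-fold higher number from compound 3 to compound 4 (0.26 log units; within the scatter) that is small, at most a modest move toward weaker inhibition of growth, and possibly none beyond the scatter. Compound 4 is therefore estimated at 1800 nM, within a range from 600 nM to 6000 nM.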

Compound 4, concentration for 50% growth inhibition: 1000 nM
Compound 4: the middle estimate sits 1.8-fold (0.26 log units) above what was measured; low and high end bracket the measured number.
By their numbers in this assay, from the lowest: compounds 3 and 4 (each within the scatter of the next); then compounds 1 and 2 (each within the scatter of the next).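

In this assay, chloro in place of bromo on an aromatic carbon, para to a large group, gives no change at the digits printed from compound 3 to compound 4 (within the scatter), so this position does not separate the 4-bromophenyl ketone from the 4-chlorophenyl ketone. Compound 4 also gives the first single-change links to the other two compounds, and both steps are much larger: 2-methoxyphenyl in place of 1H-pyrrol-2-yl gives a 10-fold lower number from compound 2 to compound 4 (1.00 log units; beyond the scatter), and hydrogen in place of chloro on an aromatic carbon gives a 10-fold lower number from compound 1 to compound 4 (1.00 log units; beyond the scatter). No measurement shown here offers an explanation for the size of any of these steps.

The compounds shown leave open how the read-out responds to fluoro, a nitrile or a carboxylic acid at the place held by bromo and chloro, as only these two halogens are compared there with the rest of the structure unchanged. They also leave open whether the two larger steps would hold with 4-bromophenyl in place of 4-chlorophenyl, and how an amine on the 2-methoxyphenyl group would affect growth inhibition.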